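Aryl swap on the cyclopropyl amide: phenyl to pyrimidinyl

This account rests on a few compounds, and the source may have more. Where it says the series, first, only, none or still open, it means among the compounds named here.

Compound 3 `CC[C@H](C)[C@H](N)CN(C(=O)[C@@H]1C[C@H]1c1ccccc1F)c1ccc(-c2ccccc2)cc1` gives 650 nM in a functional assay for agonist activity at G protein-coupled receptor 88 (Homo sapiens), read by HTRF and cAMP accumulation (on this read-out higher numbers stand for an effect only at larger amounts of compound and lower numbers for an effect already at smaller amounts), and stands highest of the three measured numbers. Its nearest neighbour is compound 2 `CC(C)(C)[C@H](N)CN(C(=O)[C@@H]1C[C@H]1c1ccccc1)c1ccc(-c2ccccc2)cc1`, which gives 11 nM; furthest is compound 1 `CC[C@@H](C)[C@H](N)CN(C(=O)[C@@H]1C[C@H]1c1ccccc1)c1ccc(-c2ccccc2)cc1`, which gives 1.4 nM. Among the measured compounds shown here, the only measured single-point step is a 7.9-fold higher number from compound 1 to compound 2 (0.90 log units; beyond the scatter), and it concerns the chain substituent, not the aryl group on the cyclopropane. For the measured compounds named here, compound 3 and compound 1 differ in more than one place, so their two values show only that compound 3 sits far above compound 1.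

Compound 4 `CC[C@H](C)[C@H](N)CN(C(=O)[C@@H]1C[C@H]1c1cncnc1)c1ccc(-c2ccccc2)cc1` differs from compound 3 by pyrimidin-5-yl in place of 2-fluorophenyl on a saturated ring carbon. Going by the values given here, no measured step touches this aryl group, so nothing here sets the size or direction of the change in this assay. The estimate therefore stays near compound 3 with a wide range. Compound 4 is expected to give 1000 nM, within 200 nM to 5000 nM. This estimate means a 1.5-fold higher number from compound 3 to compound 4 (0.19 log units; within the scatter).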

Compound 4, half-maximal effective concentration: 19000 nM
Estimate against measurement, compound 4: 19-fold (1.28 log units) below; the whole stated range lies below it.
By their numbers in this assay, from the lowest: compound 1; then compound 2; then compound 3; then compound 4.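

The aryl group on a saturated ring carbon strongly affects the read-out in this assay: pyrimidin-5-yl in place of 2-fluorophenyl gives a 29-fold higher number from compound 3 to compound 4 (1.47 log units; beyond the scatter), whereas the earlier single-place step, a 7.9-fold higher number from compound 1 to compound 2 (0.90 log units; beyond the scatter), concerned only the chain substituent. The change replaces a carbon-only aromatic ring with no hydrogen-bond acceptors by an aromatic ring with 2 hetero atoms and 2 hydrogen-bond acceptors, and it also removes the fluorine, so this one step cannot separate these differences. No measurement shown accounts for the size of the step.

As far as these compounds go, whether pyridin-3-yl, with a single ring nitrogen, would give a step of similar size remains open. Also open, from the compounds shown here alone, is how 2-fluorophenyl compares with plain phenyl on the same chain, since compound 1 and compound 3 differ in more than one place.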